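Cyclopropyl to Hydroxyphenyl Ketone on a Shared Core

The source may report more compounds than this note shows. Statements on the series, on what has been measured and on what is new or still open speak of the compounds shown alone.

Compound 1 `COc1cc(C(=O)C2Sc3nnc(-c4cc(OC)c(OC)c(OC)c4)n3NC2c2ccco2)cc(OC)c1OC` gives 52200 nM in a functional assay on PC-3 cells (Homo sapiens) for cytotoxicity, read by MTT assay, with a stated time of 48 h; on this read-out higher numbers stand for weaker inhibition and lower numbers for stronger inhibition.
Compound 2 `COc1cc(-c2nnc3n2NC(c2ccco2)C(C(=O)c2cccs2)S3)cc(OC)c1OC` gives 46200 nM in this assay.
Compound 3 `COc1cc(-c2nnc3n2NC(c2ccco2)C(C(=O)C2CC2)S3)cc(OC)c1OC` gives 95200 nM in this assay.

Compound 3 carries the highest of the three numbers. The step of a 1.8-fold higher number from compound 1 to compound 3 (0.26 log units; within the scatter) falls within the scatter, whereas the step of a 2.1-fold higher number from compound 2 to compound 3 (0.31 log units; beyond the scatter) lies beyond it. Compound 4 `COc1cc(-c2nnc3n2NC(c2ccco2)C(C(=O)c2ccc(O)cc2)S3)cc(OC)c1OC` differs from compound 3 in one place: 4-hydroxyphenyl in place of cyclopropyl on a carbonyl carbon. Among the compounds with values here, two measured steps bear on this change, as both replace an aromatic ring on the carbonyl carbon with cyclopropyl: a 1.8-fold higher number from compound 1 to compound 3 (0.26 log units; within the scatter) and a 2.1-fold higher number from compound 2 to compound 3 (0.31 log units; beyond the scatter). Both raised the number, one within and one just beyond the scatter. Reversing the direction, a move from cyclopropyl back to an aromatic ring is expected to lower the number by a modest amount in this assay, though no measured pair includes a hydroxyl-bearing ring. The expected step is therefore a 1.9-fold lower number from compound 3 to compound 4 (0.28 log units; within the scatter). Compound 4 is estimated to give about 50000 nM in this assay, with a range from 20000 nM to 120000 nM.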

Compound 4, half-maximal inhibitory concentration: 38300 nM
Compound 4: the middle estimate sits 1.3-fold (0.12 log units) above what was measured; the range from low to high includes it.
By their numbers in this assay, from the lowest: compounds 4, 2, 1 and 3 (each within the scatter of the next, the first and the last beyond it).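

In this assay, 4-hydroxyphenyl on the carbonyl carbon gives a clear separation from cyclopropyl (a 2.5-fold lower number from compound 3 to compound 4 (0.40 log units; beyond the scatter)), so a ring bearing a hydroxyl, new at this place, also goes with a lower number than cyclopropyl. Against the other two aromatic groups it stays within the scatter, both for thiophen-2-yl (a 1.2-fold lower number from compound 2 to compound 4 (0.08 log units; within the scatter)) and for 3,4,5-trimethoxyphenyl (a 1.4-fold lower number from compound 1 to compound 4 (0.13 log units; within the scatter)), so these three groups cannot be told apart here, while compound 3 stands beyond the scatter from compound 2 and compound 4 but not from compound 1. Nothing at hand accounts for these differences.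

As far as these compounds go, it remains open whether the hydroxyl itself plays any part in the value of compound 4. Also open, from the compounds shown here alone, is what a plain phenyl ring, an amine on the ring, or a longer alkyl chain in place of cyclopropyl would give.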